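A trimethoxyphenyl swap on compound 2

The source may report more compounds than this note shows. Statements on the series, on what has been measured and on what is new or still open speak of the compounds shown alone.

In a functional assay on HepG2 cells (Homo sapiens) for cytotoxicity, read by MTT assay, with a stated time of 72 h (a higher number here means a weaker inhibitor, a lower number a stronger inhibitor), compound 1 `N#Cc1ccc(/C=N/NC(=O)Nc2cc3c(Nc4ccc(F)c(Cl)c4)ncnc3cc2O[C@H]2CCOC2)cc1` gives 26400 nM and compound 2 `COc1cc2ncnc(Nc3ccc(F)c(Cl)c3)c2cc1NC(=O)N/N=C/c1ccc(C#N)cc1` gives 34100 nM with the two values within the scatter of each other. Compound 3 `COc1cc2ncnc(Nc3ccc(F)c(Cl)c3)c2cc1NC(=O)N/N=C/c1ccc(OC)c(OC)c1OC` has 2,3,4-trimethoxyphenyl in place of 4-cyanophenyl on a carbon with a double bond to nitrogen. Among the compounds with values here, the only measured step, a 1.3-fold higher number from compound 1 to compound 2 (0.11 log units; within the scatter) and so within the scatter, lies at a different place and bears only indirectly on this change. In this assay no step beyond the scatter is expected, the estimated step being a 1.4-fold lower number from compound 2 to compound 3 (0.13 log units; within the scatter) for now. Compound 3 is estimated at 25000 nM with an expected range of 9000 nM to 70000 nM in this assay.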

Compound 3, half-maximal inhibitory concentration: 31200 nM
Compound 3: the middle estimate sits 1.2-fold (0.10 log units) below what was measured; measured number inside the range.
By their numbers in this assay, from the lowest: compounds 1, 3 and 2 (each within the scatter of the next).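

In this assay, the exchange of 4-cyanophenyl for 2,3,4-trimethoxyphenyl on a carbon with a double bond to nitrogen gives a 1.1-fold lower number from compound 2 to compound 3 (0.04 log units; within the scatter) and so stays within the scatter. Within the data shown here, this is the first measured change at this position, and it shows that these two rings, one with a nitrile and one with methoxy groups, cannot be told apart in this read-out. Nothing at hand bears on the reason for this result.

As far as these compounds go, whether an amine or a carboxylic acid on this ring would move the number beyond the scatter remains open. So does whether 2,3,4-trimethoxyphenyl would read the same with the oxolan-3-yl group of compound 1 in place of methyl.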